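The compounds below may be only part of what the source reports. "The series", "measured", "known", "first", "only" and "open" are said of these compounds alone.

Measured in a functional assay on MDA-MB-231 cells (Homo sapiens) for cytotoxicity, read by MTT assay, with a stated time of 24 h; on this read-out lower numbers stand for stronger inhibition and higher numbers for weaker inhibition:
Compound 1 `Cc1ccc(-c2nnc(CNC(=O)CN)o2)cc1`: 260 nM
Compound 2 `COc1ccc(-c2nnc(CNC(=O)CN)o2)cc1`: 276 nM

In this assay, compound 2 at 276 nM sits level with compound 1, within the scatter. Compound 3 `NCC(=O)NCc1nnc(-c2ccc([N+](=O)[O-])cc2)o1` follows from compound 2 by nitro in place of methoxy on an aromatic carbon. Going by the values given here, the one measured step that bears on this change is a 1.1-fold higher number from compound 1 to compound 2 (0.03 log units; within the scatter), with methoxy in place of methyl on an aromatic carbon, and it stayed within the scatter. Among the compounds with values here, no nitro compound has been measured, so this evidence is thin, and no step beyond the scatter is expected. The expected change is a 1.0-fold lower number from compound 2 to compound 3 (0.02 log units; within the scatter). Compound 3 is estimated at 265 nM, with an expected range of 100 nM to 700 nM.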

Compound 3, half-maximal inhibitory concentration: 276 nM
Compound 3: the middle estimate sits 1.0-fold (0.02 log units) below what was measured; the measured number falls inside the stated range.
By their numbers in this assay, from the lowest: compounds 1, 2 and 3 (each within the scatter of the next).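

In this assay, nitro in place of methoxy on an aromatic carbon para to a large group gives no change at the digits printed from compound 2 to compound 3 (within the scatter) and nitro in place of methyl gives a 1.1-fold higher number from compound 1 to compound 3 (0.03 log units; within the scatter) at the same place. Methyl, methoxy and nitro thus all read level here, so this position has now tolerated a third group, and one with a different atom count, without any step beyond the scatter. Nothing at hand accounts for this level reading.

As far as these compounds go, whether an amine or a carboxylic acid at this place would move the number remains open. So does the effect of a longer chain carrying the terminal amine on the other side of the shared core.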